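The source may report more compounds than this note shows. Statements on the series, on what has been measured and on what is new or still open speak of the compounds shown alone.

In an ADME assay on HEK293 cells (Homo sapiens) for cytotoxicity, read by MTT assay, with a stated time of 72 h (on this read-out lower numbers stand for stronger inhibition and higher numbers for weaker inhibition), compound 1, `COc1ccc(C2=C(c3cc(OC)c(OC)c(OC)c3)C(=O)CC2O[SiH2]C(C)(C)C)cc1OC`, gives only a limit of the assay, > 100 ug/mL. Compound 3, `C=CCOc1cc(C2=C(c3cc(OC)c(OC)c(OC)c3)C(=O)C(O)C2)ccc1OC`, likewise gives in this assay only a limit, > 100 ug/mL. Among the compounds with values here, compound 2, `COc1ccc(C2=C(c3cc(OC)c(OC)c(OC)c3)C(=O)C(OC(C)=O)C2)cc1O`, is the one member of the trio with a number in this assay, 92 ug/mL. Within the data shown here, compound 1 thus stands at the limit of > 100 ug/mL in this assay, at which 2 of the 3 values shown sit, and there is no measured step between compounds that differ in one place from which the weight of a single change could be read; the values of compound 1 and compound 3 show only that both lie beyond the reach of the assay, and the value of compound 2 sits not far from that same boundary.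

Compound 4, `COc1ccc(C2=C(c3cc(OC)c(OC)c(OC)c3)C(=O)CC2O[SiH2]C(C)(C)C)cc1`, has not yet been measured in this assay. It differs from compound 1 by hydrogen in place of methoxy on an aromatic carbon; read one bond further out, the change turns a 3,4-dimethoxyphenyl into a 4-methoxyphenyl on the shared core. Among the measured compounds shown here, with compound 1 already at a limit and no measured step of this kind to lean on, the step is expected to be none beyond the scatter, a number no higher from compound 1 to compound 4 (the limit leaves the size open). Compound 4 is therefore estimated at 100 ug/mL, expected to fall between 50 ug/mL and 200 ug/mL, with a real chance that this assay again reports only a limit.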

Compound 4, half-maximal inhibitory concentration: > 100 ug/mL
Compound 4 was reported as a limit (the forecaster's own chance of this, stated with the estimate: 60%); the middle value lies on the limit itself.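

In this assay compound 4 also gives only a limit, > 100 ug/mL, and with compound 1 at a limit as well, no step can be read between compound 1 and compound 4: the limit of > 100 ug/mL in this assay, at which 3 of the 4 values shown sit. The compounds shown leave open what hydrogen in place of methoxy does to the value in this assay.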